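The source may hold more compounds than are shown below. What is called first, only, known or untested is meant among the compounds shown, and "the series" means these compounds.

Compound 2 `COc1cccc(NC(=O)NC2CC(C)(C)Oc3ccc(F)cc32)c1` is a urea linking a methoxy-bearing aromatic ring to a fused bicyclic core that carries a fluoro group. Measured in a functional assay (aorta) with Rattus norvegicus as the target (on this read-out higher numbers stand for an effect only at larger amounts of compound and lower numbers for an effect already at smaller amounts), compound 2 reaches only the limit of the method, > 10000 nM, so no true number is known for it. Compound 1 `COc1ccccc1NC(=O)NC1CC(C)(C)Oc2ccc(Cl)cc21` shares the urea and the core but differs in two places; in this assay compound 1 likewise stops at the limit, > 10000 nM. Both measured compounds thus sit at the limit of > 10000 nM in this assay, at which 2 of the 2 values shown sit. Compound 3 `COc1cccc(NC(=O)NC2CC(C)(C)Oc3ccc(Cl)cc32)c1` arises from compound 2 by a single exchange, (chloro in place of fluoro on an aromatic carbon), that is, chloro in place of fluoro on an aromatic carbon. Among the compounds with values here, no measured pair shows what this swap does here. The step from compound 2 to compound 3 is expected to be small, a step that the limit leaves unreadable from compound 2 to compound 3. Compound 3 is therefore estimated at 15000 nM in this assay, in a range from 3000 nM to 60000 nM, with a fair chance that only a limit is reported again.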

Compound 3, half-maximal effective concentration: > 10000 nM
Compound 3: no number, only a limit; the forecaster's own chance of this, stated with the estimate: 65%; the middle value lies beyond the limit too.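

Compound 3 also gives only a limit, > 10000 nM, so its steps from compound 2 and from compound 1 cannot be read: the limit of > 10000 nM in this assay, at which 3 of the 3 values shown sit. The compounds shown leave open what chloro in place of fluoro, or 3-methoxyphenyl in place of 2-methoxyphenyl, does in this assay.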